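From isopropyl to cyclopentyl on the shared core

The source may report more compounds than this note shows. Statements on the series, on what has been measured and on what is new or still open speak of the compounds shown alone.

Of the compounds shown here, three have been measured in a functional assay on HCT-116 cells (Homo sapiens) for antiproliferative activity, read by CCK-8 assay, with a stated time of 72 h; a lower number here means a stronger inhibitor, a higher number a weaker inhibitor. In it, compound 1 `CCC(C)n1cnc2c(NCc3ccc(C(=O)Nc4ccccc4N)cc3)nc(Cl)nc21` gives 720 nM, compound 2 `Nc1ccccc1NC(=O)c1ccc(Cn2cnc3c(Nc4ccccc4)nc(Cl)nc32)cc1` gives 1070 nM and compound 3 `CC(C)n1cnc2c(NCc3ccc(C(=O)Nc4ccccc4N)cc3)nc(Cl)nc21` gives 800 nM. Compound 3 lies within the scatter of both other compounds, so its place among the three carries no ranking.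

Compound 4 `Nc1ccccc1NC(=O)c1ccc(CNc2nc(Cl)nc3c2ncn3C2CCCC2)cc1`, not yet measured, has cyclopentyl in place of isopropyl on an aromatic nitrogen. Among the compounds with values here, only one measured step touches the group on that nitrogen: a 1.1-fold higher number from compound 1 to compound 3 (0.05 log units; within the scatter). It places hydrogen in place of methyl on a saturated chain carbon, two bonds along the chain from an aromatic nitrogen, and it stays within the scatter. Within the data shown here, compound 2 differs from compound 3 in more than one place and offers no such step. Among the measured compounds shown here, no measured compound carries cyclopentyl, so the evidence is indirect.

Resting on compound 3 at 800 nM and on a 1.1-fold higher number from compound 1 to compound 3 (0.05 log units; within the scatter), the expectation in this assay is no step beyond the scatter, with neither direction favoured. The estimated step is a 1.1-fold lower number from compound 3 to compound 4 (0.06 log units; within the scatter). Compound 4 is expected at 700 nM, with an estimated range from 330 nM to 1500 nM.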

Compound 4, half-maximal inhibitory concentration: 850 nM
Compound 4: the middle estimate sits 1.2-fold (0.08 log units) below what was measured, within the range that was stated.
By their numbers in this assay, from the lowest: compounds 1, 3, 4 and 2 (each within the scatter of the next).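

In this assay, within the data shown here, the aromatic nitrogen now carries a ring for the first time: cyclopentyl, with 5 heavy atoms and one five-membered non-aromatic ring of carbon only, takes the place of isopropyl, with 3 heavy atoms and no ring, and the change gives a 1.1-fold higher number from compound 3 to compound 4 (0.03 log units; within the scatter) and so stays within the scatter. Set against sec-butyl, cyclopentyl gives a 1.2-fold higher number from compound 1 to compound 4 (0.07 log units; within the scatter) and again stays within the scatter, so in this assay the open chains of compound 1 and compound 3 and the ring of compound 4 cannot be told apart. No supporting measurement bears on why these groups read alike.

Going by these compounds, whether a different kind of group on this nitrogen, such as a phenyl ring, a piperidine or a chain ending in a carboxylic acid, would give a step beyond the scatter remains open. On these data alone, it is also open whether the cyclopentyl group would read the same way if the chlorine on the shared core were replaced by an amine.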